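The compounds below may be only part of what the source reports. "The series", "measured", "known", "first", "only" and "open" are said of these compounds alone.

Compound 1 `COc1ccc(C2CC(c3ccc(OC)c(OC)c3)=NN2)c(OC)c1` and compound 2 `COc1ccc(C2=NN(C(=O)CBr)C(c3ccco3)C2)cc1OC` were each examined in a functional assay on the whole organism (strain albino) for inhibition, with Rattus norvegicus as the target, read by paw edema, with stated times of 30 min and 1 h, at a dose of 100 mg/kg by the oral route; on this read-out lower numbers stand for less inhibition and higher numbers for more inhibition at the one dose given (going by the name of the read-out). Compound 1 gives 38% in this assay, and compound 2 gives 38%. Compound 1 therefore stands level with compound 2 at the digits reported, its nearest neighbour, the two values lying within the scatter of each other. Among the measured compounds shown here, no single-site step between measured compounds is available, so the data give no measured direction for any one change. Compound 3 `COc1ccc(C2CC(c3ccc(OC)c(OC)c3)=NN2C(=O)C(C)Br)c(OC)c1` has not yet been measured. It differs from compound 1 by (1-bromoethyl)carbonyl in place of hydrogen on an amine nitrogen in a ring. As far as these compounds go, since the two measured readings coincide and this particular change is untested, compound 3 is expected to show a step of a number 2 percentage points higher from compound 1 to compound 3 (within the scatter), that is, none beyond the scatter. The estimate for compound 3 in this assay is 40%, with an expected range from 25% to 55%.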

Compound 3, a percentage reported as inhibition, in the whole organism at one dose (the size of the read-out at that dose, not a potency): 58%
Compound 3: middle estimate off by 18 percentage points, on the low side, and the stated range ends below it.
By their numbers in this assay, from the lowest: compounds 1 and 2 (each within the scatter of the next); then compound 3.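

In this assay, among the compounds shown here, (1-bromoethyl)carbonyl in place of hydrogen on an amine nitrogen in a ring gives a number 20 percentage points higher from compound 1 to compound 3 (beyond the scatter) and so provides the only single-site step in this set. The amine nitrogen of the core of compound 1 therefore accepts this substitution without loss of the reading, and the substituted compound shows more inhibition at the one dose given. Nothing measured here explains the step.

The compounds shown leave open whether the bromine is needed or whether a plain propanoyl group on the same nitrogen would give a similar reading. They also leave open how an aminoacetyl group or a longer acyl chain at this position would read, and whether the same step would hold on the other aryl groups of the series.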